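The compounds below may be only part of what the source reports. "The series", "measured", "known", "first", "only" and "open" are said of these compounds alone.

Compound 1 `Cc1ccc(S/C(=C/c2ccc(Br)cc2)C(=O)c2ccc(Cl)cc2)cc1`: 25000 nM
Compound 2 `O=C(/C(=C\c1ccc(Br)cc1)Sc1ccc(Br)cc1)c1ccc(Br)cc1`: 1000 nM
Compound 3 `Cc1cc(C)cc(/C=C(/Sc2ccc(Br)cc2)C(=O)c2ccc(Cl)cc2)c1`: 10000 nM

In a functional assay on DU-145 cells (Homo sapiens) for inhibition, read by trypan blue exclusion, with a stated time of 96 h (on this read-out higher numbers stand for weaker inhibition of growth and lower numbers for stronger inhibition of growth), compound 3 gives 10000 nM, the middle of the three values, with compound 1 higher and compound 2 lower, both beyond the scatter. Compound 4 `O=C(/C(=C\c1ccc(Br)cc1)Sc1ccc(Br)cc1)c1ccc(Cl)cc1` is next: 4-bromophenyl in place of 3,5-dimethylphenyl on a double-bonded chain carbon bound to a double-bonded chain carbon, with 4-bromophenyl in place of 3,5-dimethylphenyl. That group also occurs at this place in compound 1, at 25000 nM, and in compound 2, at 1000 nM, so it does not fix the value alone. A fall in this assay beyond the scatter is expected, leaning towards compound 2 at 1000 nM. The estimated change is a 4.0-fold lower number from compound 3 to compound 4 (0.60 log units; beyond the scatter). For compound 4 the expected value is 2500 nM, with an estimated range of 700 nM to 9000 nM.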

Compound 4, concentration for 50% growth inhibition: 1000 nM
The estimate for compound 4 lay 2.5-fold (0.40 log units) above the measured number; the range from low to high includes it.
By their numbers in this assay, from the lowest: compounds 2 and 4 (each within the scatter of the next); then compound 3; then compound 1.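

In this assay there is a 10-fold lower number from compound 3 to compound 4 (1.00 log units; beyond the scatter) with 4-bromophenyl in place of 3,5-dimethylphenyl on a double-bonded chain carbon bound to a double-bonded chain carbon, and a 25-fold lower number from compound 1 to compound 4 (1.40 log units; beyond the scatter) with bromo in place of methyl on an aromatic carbon. There is no change at the digits printed from compound 2 to compound 4 (within the scatter) with chloro in place of bromo on an aromatic carbon, so these two halogens are not told apart at that place. Nothing at hand speaks to the cause of these steps. Open, from the compounds shown here alone, is how an amine, a methoxy group or a carboxylic acid in place of the halogen on the aromatic carbon would read.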